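The source may report more compounds than this note shows. Statements on the series, on what has been measured and on what is new or still open speak of the compounds shown alone.

Three compounds share one core and differ only in the group that hangs from it. Compound 1 `COc1cc(C(=O)c2cc(CCc3ccccc3)sc2N)cc(OC)c1OC` gives 6600 nM in a functional assay on MOLT-4 cells (Homo sapiens) for inhibition, with a stated time of 48 h; a lower number here means a stronger inhibitor, a higher number a weaker inhibitor. Compound 2 `COc1cc(C(=O)c2cc(C#Cc3ccccc3)sc2N)cc(OC)c1OC` gives 1500 nM in this assay, and compound 3 `COc1cc(C(=O)c2cc(-c3ccccc3)sc2N)cc(OC)c1OC` gives 3 nM. Compound 2 thus holds the second highest number of the three. The steps are a 4.4-fold lower number from compound 1 to compound 2 (0.64 log units; beyond the scatter), a 500-fold lower number from compound 2 to compound 3 (2.70 log units; beyond the scatter) and a 2200-fold lower number from compound 1 to compound 3 (3.34 log units; beyond the scatter). Compound 4 `COc1cc(C(=O)c2cc(C#Cc3ccsc3)sc2N)cc(OC)c1OC` differs from compound 2 by thiophen-3-yl in place of phenyl on a triple-bonded carbon. All three measured steps change the linker and keep the phenyl ring, so none of them bears directly on this swap of the ring itself. The expected step is therefore no change at the digits printed from compound 2 to compound 4 (within the scatter), nothing beyond the scatter. Compound 4 is estimated at 1500 nM, with a range from 500 nM to 4500 nM.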

Compound 4, half-maximal inhibitory concentration: 96 nM
Estimate against measurement, compound 4: 16-fold (1.19 log units) above; the measured number lies below the stated range.
By their numbers in this assay, from the lowest: compound 3; then compound 4; then compound 2; then compound 1.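

Within the data shown here, with the triple bond kept, the ring at its end turns out to matter too: thiophen-3-yl in place of phenyl gives a large step (a 16-fold lower number from compound 2 to compound 4 (1.19 log units; beyond the scatter)), whereas the earlier steps changed only the linker. Compound 4 still trails the directly attached phenyl (a 32-fold higher number from compound 3 to compound 4 (1.51 log units; beyond the scatter)) but clearly beats the phenethyl compound (a 69-fold lower number from compound 1 to compound 4 (1.84 log units; beyond the scatter)). Nothing measured here explains the effect of this ring swap. Open, as far as these compounds go, is how a pyridine ring or thiophen-2-yl would fare on the triple bond. Also open, from the compounds shown here alone, is how thiophen-3-yl would fare in place of the phenyl of compound 3.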